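Two chloro groups on the aryl ring of a pyrrole acid

The source may hold more compounds than are shown below. What is called first, only, known or untested is meant among the compounds shown, and "the series" means these compounds.

This series concerns inhibition of Notum, measured in an assay on cells for inhibition of Palmitoleoyl-protein carboxylesterase NOTUM variant C330S (Homo sapiens), read by fluorescence, with a stated time of 40 min; a higher number here means a weaker inhibitor, a lower number a stronger inhibitor. Compound 1 `Cc1cc(C(=O)O)c(C)n1-c1ccccc1Cl` gives 2300 nM, and compound 2 `Cc1cc(C(=O)O)c(C)n1-c1cccc(Cl)c1` gives 430 nM; how compound 1 and compound 2 differ is not broken down here. Compound 3 `Cc1cc(C(=O)O)c(C)n1-c1ccc(Cl)cc1Cl` gives 430 nM, and the step of a 5.3-fold lower number from compound 1 to compound 3 (0.73 log units; beyond the scatter) was a chloro in place of hydrogen on an aromatic carbon. Compound 4 `Cc1cc(C(=O)O)c(C)n1-c1cc(Cl)cc(Cl)c1` carries the same kind of change from compound 2, (chloro in place of hydrogen on an aromatic carbon), though its place is meta to a large group rather than para to a large group. Compound 4 is expected to give 200 nM in this assay, a step of a 2.2-fold lower number from compound 2 to compound 4 (0.33 log units; beyond the scatter), which rests on the step of a 5.3-fold lower number from compound 1 to compound 3 (0.73 log units; beyond the scatter) and on compound 2 already giving 430 nM.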

Compound 4, half-maximal inhibitory concentration: 850 nM
Compound 4: middle estimate off by 4.3-fold (0.63 log units), on the low side, and the stated range ends below it.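

In this assay the added chloro group gives a 2.0-fold higher number from compound 2 to compound 4 (0.30 log units; within the scatter) and so brings no gain on this core. Set beside the earlier step, the same change does not carry over from one core to the other: the same change on two cores in this assay, a 5.3-fold lower number (0.73 log units; beyond the scatter) from compound 1 to compound 3 and a 2.0-fold higher number (0.30 log units; within the scatter) from compound 2 to compound 4, 11-fold (1.02 log units) apart, beyond the scatter of two such steps.

This shows that, for these two pairs, the outcome of adding a chloro group depends on the compound that receives it. It does not show whether the starting core or the place of the new chloro group accounts for the gap, and two pairs give no rule for other cores.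

The compounds shown leave open how a fluoro, methoxy or nitrile group would compare with chloro at these places on the aryl ring.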